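The source may hold more compounds than are shown below. What is called first, only, known or untested is meant among the compounds shown, and "the series" means these compounds.

This account concerns an ADME assay on Vero cells (Chlorocebus sabaeus) for cytotoxicity, with a stated time of 72 h (a lower number here means a stronger inhibitor, a higher number a weaker inhibitor), and two compounds whose structures are `COc1ccc(-c2cccc(CO[C@@H]3COc4nc([N+](=O)[O-])cn4C3)c2)cc1F` for compound 1 and `O=[N+]([O-])c1cn2c(n1)OC[C@@H](OCc1cc(-c3ccc(C(F)(F)F)cc3)no1)C2` for compound 2. In this assay compound 1 returns > 128000 nM, which is a limit rather than a number. Compound 2 likewise returns > 128000 nM, again a limit of the assay and not a measured number. For the measured compounds named here, compound 2 therefore stands at the same point as the only other value shown, namely (the limit of > 128000 nM in this assay, at which 2 of the 2 values shown sit), so no ordering between the two can be drawn.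

A third compound, compound 3, has the structure `N#Cc1ccc(-c2cc(CO[C@@H]3COc4nc([N+](=O)[O-])cn4C3)on2)cc1` and has yet to be measured. It differs from compound 2 by cyano in place of trifluoromethyl on an aromatic carbon. Going by the values given here, no step between measured compounds is available to guide the expectation, so compound 3 is expected to show no step beyond the usual scatter, with a step that the limit leaves unreadable from compound 2 to compound 3 estimated for the change from compound 2. Compound 3 is thus estimated at 150000 nM, with a range from 60000 nM to 400000 nM, most likely reported again as a limit.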

Compound 3, half-maximal inhibitory concentration: > 128000 nM
Compound 3 ended at the assay's limit; the forecaster's own chance of this, stated with the estimate: 85%; the middle value does not contradict the limit.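

Compound 3, like compound 2, ends at a limit of this assay and not at a number, so no step can be read for cyano in place of trifluoromethyl: the limit of > 128000 nM in this assay, at which 3 of the 3 values shown sit.

The compounds shown leave open what concentration of any of the three would reach half-maximal inhibition in this assay.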